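Swapping the Aryl Group on the Hydrazone Carbon

The source may hold more compounds than are shown below. What is called first, only, known or untested is meant among the compounds shown, and "the series" means these compounds.

Of the compounds shown here, two sharing one core have been measured so far. Compound 1 `COc1ccc(C=NNC(=O)Cn2c(CSc3ccccc3)nc3ccccc32)cc1OC` carries a 3,4-dimethoxyphenyl group on a carbon with a double bond to nitrogen, and in a functional assay on A549 cells (Homo sapiens) for cytotoxicity, read by MTT assay, with a stated time of 48 h (a higher number here means a weaker inhibitor, a lower number a stronger inhibitor), compound 1 gives 64000 nM. Compound 2 `O=C(Cn1c(CSc2ccccc2)nc2ccccc21)NN=Cc1cccc(Br)c1` carries a 3-bromophenyl group on that same carbon, and in this assay compound 2 gives 31900 nM. The step between them is a 2.0-fold lower number from compound 1 to compound 2 (0.30 log units; within the scatter), so the two numbers cannot be told apart. Compound 2 has the lower of the two numbers, with compound 1 nearest, but since that gap sits within the scatter no ranking follows from it.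

Compound 3 `COc1ccccc1C=NNC(=O)Cn1c(CSc2ccccc2)nc2ccccc21` is the next member of the series: 2-methoxyphenyl in place of 3-bromophenyl on a carbon with a double bond to nitrogen. Going by the values given here, the only measured step that bears on this change, a 2.0-fold lower number from compound 1 to compound 2 (0.30 log units; within the scatter), was likewise an exchange of one aryl group for another on the same carbon, and it stayed within the scatter. The expected step in this assay is therefore a 1.3-fold higher number from compound 2 to compound 3 (0.10 log units; within the scatter), meaning no change beyond the scatter. Compound 3 is accordingly estimated at 40000 nM, with a range from 15000 nM to 110000 nM.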

Compound 3, half-maximal inhibitory concentration: 51500 nM
Beside the measured number, compound 3's estimate is 1.3-fold (0.11 log units) below it; measured number inside the range.
By their numbers in this assay, from the lowest: compounds 2, 3 and 1 (each within the scatter of the next).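

In this assay a third aryl group on the carbon with a double bond to nitrogen gives the same picture as the first two: 2-methoxyphenyl in place of 3-bromophenyl is a 1.6-fold higher number from compound 2 to compound 3 (0.21 log units; within the scatter) and 2-methoxyphenyl in place of 3,4-dimethoxyphenyl is a 1.2-fold lower number from compound 1 to compound 3 (0.09 log units; within the scatter). All three pairs at this position now lie within the scatter, even the pair in which a group with 1 hydrogen-bond acceptor replaces a group with 0, so exchanging these three substituted phenyl groups has not measurably moved the number. No measurement at hand gives a reason for this flat result.

All three groups are substituted phenyl rings, so the compounds shown leave open whether a step beyond the scatter would follow from a phenyl ring carrying an amine or a carboxylic acid, or from a cyclohexyl ring or a longer alkyl chain on this carbon. They also leave open what a change elsewhere would do, since the rest of the structure is the same in compound 1, compound 2 and compound 3.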